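Acetyl in place of 1-hydroxyethyl on compound 3

A few compounds are considered here, and "the series" means these few. Any claim that something is new, unique, unknown or untested is made for them only; others in the source may bear on it.

Measured so far in a functional assay on VCaP cells (Homo sapiens) for antiproliferative activity, read by CCK-8 assay, with a stated time of 6 days; on this read-out lower numbers stand for stronger inhibition and higher numbers for weaker inhibition
- compound 1 `C[C@@H](Cn1ccc(-c2ccc(C#N)c(Cl)c2)n1)NC(=O)c1cccc(OCC(O)CO)c1` gives 590 nM
- compound 2 `CC(Cn1ccc(-c2ccc(C#N)c(Cl)c2)n1)C(=O)Nc1cc[nH]n1` gives > 30000 nM, a limit
- compound 3 `CC(Cn1ccc(-c2ccc(C#N)c(Cl)c2)n1)C(=O)Nc1cccc(C(C)O)c1` gives > 30000 nM, a limit
- compound 4 `CC(=O)c1cccc(NC(=O)C(C)Cn2ccc(-c3ccc(C#N)c(Cl)c3)n2)c1` has not yet been measured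

Compound 3 offers no number to start from, since it sits at the limit of > 30000 nM in this assay, at which 2 of the 3 values shown sit. Compound 1 is the only one of the three with a numerical value.

Compound 4 differs from compound 3 by one change, (acetyl in place of 1-hydroxyethyl on an aromatic carbon), with acetyl in place of 1-hydroxyethyl on an aromatic carbon. Among the measured compounds shown here, the one measured step that bears on this change is a step that the two limits leave unreadable from compound 2 to compound 3, so no size can be carried over from it. For the measured compounds named here, no measured step therefore points to a move in either direction, and compound 4 is expected to stay close to the limit of this assay. The expected step is an at least 1.2-fold lower number from compound 3 to compound 4 (0.07 log units; that floor lies within the scatter), with no direction readable beyond the scatter. Compound 4 is estimated at 25000 nM, with an expected range from 9000 nM to 40000 nM.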

Compound 4, half-maximal inhibitory concentration: 2980 nM
Estimate against measurement, compound 4: 8.4-fold (0.92 log units) above; measured number outside the range, below it.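

In this assay, this position gives its first readable step: an at least 10-fold lower number from compound 3 to compound 4 (1.00 log units; beyond the scatter), with acetyl in place of 1-hydroxyethyl, a change that removes the hydrogen-bond donor of the group while the count of heavy atoms stays the same. The group on the amide-type nitrogen also now shows a readable difference: an at least 10-fold lower number from compound 2 to compound 4 (1.00 log units; beyond the scatter), with 3-acetylphenyl in place of 1H-pyrazol-3-yl. Both sizes are floors rather than measured gaps, since each starts from a limit: the limit of > 30000 nM in this assay, at which 2 of the 4 values shown sit.

The compounds shown do not tell whether the loss of the donor or some other feature of the acetyl group underlies the step. They also leave open how a methyl ether, an amine or a carboxylic acid would behave at this same place on the ring.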